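Cytotoxicity notes on a benzothiazole amide series: compound 3 to compound 4

A few compounds are considered here, and "the series" means these few. Any claim that something is new, unique, unknown or untested is made for them only; others in the source may bear on it.

Compound 1 `Cc1ccc2nc(NC(=O)c3cn(-c4ccccc4)nc3-c3ccc(F)cc3)sc2c1`, compound 2 `O=C(Nc1nc2ccc(F)cc2s1)c1cn(-c2ccccc2)nc1-c1ccc(Cl)cc1` and compound 3 `O=C(Nc1nc2ccc(Cl)cc2s1)c1cn(-c2ccccc2)nc1-c1ccc(Cl)cc1` share one core and differ in two substituents. For the measured compounds named here, in an ADME assay on HEK-293T cells (Homo sapiens) for cytotoxicity, read by MTT assay, with a stated time of 72 h (on this read-out higher numbers stand for weaker inhibition and lower numbers for stronger inhibition), compound 3 gives 15700 nM, the only number in the set. Compound 1 reaches only an assay limit, > 50000 nM. Compound 2 likewise reaches only a limit, > 50000 nM. Going by the values given here, the single recorded one-point step, an at least 3.1-fold lower number from compound 2 to compound 3 (0.50 log units; beyond the scatter), is read against (the limit of > 50000 nM in this assay, at which 2 of the 3 values shown sit). Compound 4 `Cc1ccc2nc(NC(=O)c3cn(-c4ccccc4)nc3-c3ccc(Cl)cc3)sc2c1` follows from compound 3 by methyl in place of chloro on an aromatic carbon. Among the compounds with values here, no measured step covers this exact change. Compound 1 carries the same methyl at the same place and sits at a limit, whereas compound 3 gives a number. A higher number is therefore expected for compound 4 a 2.9-fold higher number from compound 3 to compound 4 (0.46 log units; beyond the scatter). Compound 4 is estimated at 45000 nM, range 15000 nM to 120000 nM.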

Compound 4, half-maximal inhibitory concentration: 35600 nM
Estimate against measurement, compound 4: 1.3-fold (0.10 log units) above; the range from low to high includes it.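

Methyl in place of chloro at this position now has a size between two real numbers in this assay, and the methyl compound stays measurable: a 2.3-fold higher number from compound 3 to compound 4 (0.36 log units; beyond the scatter). Methyl in place of fluoro gives an at least 1.4-fold lower number from compound 2 to compound 4 (0.14 log units; that floor lies within the scatter), and this step starts at an assay limit: the limit of > 50000 nM in this assay, at which 2 of the 4 values shown sit. Chloro in place of fluoro now appears twice, as an at least 3.1-fold lower number from compound 2 to compound 3 (0.50 log units; beyond the scatter) and as an at least 1.4-fold lower number from compound 1 to compound 4 (0.14 log units; that floor lies within the scatter), without a usable comparison: the same change on two cores in this assay, an at least 3.1-fold lower number (0.50 log units; beyond the scatter) from compound 2 to compound 3 and an at least 1.4-fold lower number (0.14 log units; that floor lies within the scatter) from compound 1 to compound 4; the limit leaves it open whether they differ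

Still open, on these data alone, is how an amine or a carboxylic acid at this position would read in this assay. As far as these compounds go, a longer chain in place of methyl is equally open.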